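Methoxy removal on the pendant aryl ring

The source may hold more compounds than are shown below. What is called first, only, known or untested is meant among the compounds shown, and "the series" means these compounds.

For the measured compounds named here, compound 2 `COc1ccc(-c2[nH]c3ccc(OC)cc3c2/C=C(\C#N)S(=O)(=O)c2ccccc2)cc1` gives the highest of the two numbers in a functional assay on DU-145 cells (Homo sapiens) for cytotoxicity, read by MTT assay, with a stated time of 96 h (a lower number here means that less compound is needed, a higher number that more compound is needed for the effect), with 3000 nM; its only neighbour, compound 1 `COc1ccc(-c2[nH]c3ccccc3c2/C=C(\C#N)S(=O)(=O)c2ccccc2)cc1`, gives 2000 nM in this assay, and the two lie within the scatter. Compound 3 `COc1ccc2[nH]c(-c3ccccc3)c(/C=C(\C#N)S(=O)(=O)c3ccccc3)c2c1` differs from compound 2 by hydrogen in place of methoxy on an aromatic carbon. Going by the values given here, the one measured step, methoxy in place of hydrogen on an aromatic carbon of the shared core, a 1.5-fold higher number from compound 1 to compound 2 (0.18 log units; within the scatter), concerned a different aromatic carbon and stayed within the scatter; no step on this aryl ring is available. No change beyond the scatter is therefore expected: no change at the digits printed from compound 2 to compound 3 (within the scatter). Compound 3 is estimated at 3000 nM, in the range 1500 nM to 6000 nM.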

Compound 3, half-maximal effective concentration: 10000 nM
The estimate for compound 3 lay 3.3-fold (0.52 log units) below the measured number; measured number outside the range, above it.
By their numbers in this assay, from the lowest: compounds 1 and 2 (each within the scatter of the next); then compound 3.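

Going from 4-methoxyphenyl to phenyl gives a 3.3-fold higher number from compound 2 to compound 3 (0.52 log units; beyond the scatter) in this assay, the first single change in the series to move the number beyond the scatter. This aryl position, para to a large group, therefore responds to losing methoxy, whereas adding methoxy on the shared core stayed within the scatter, with a 1.5-fold higher number from compound 1 to compound 2 (0.18 log units; within the scatter). Nothing measured here accounts for this difference. From the compounds shown here alone, whether the response is specific to methoxy remains open: a hydroxyl, a fluorine or an amine at this position would test that. Going by these compounds, whether a longer alkoxy chain there would behave like methoxy is also open.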